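Working notes: from compound 3 to compound 4

The compounds below may be only part of what the source reports. "The series", "measured", "known", "first", "only" and "open" are said of these compounds alone.

Measured in an ADME assay on Vero cells (Chlorocebus sabaeus) for cytotoxicity, read by MTT assay, with a stated time of 72 h; a lower number here means that less compound is tolerated, a higher number that more compound is tolerated:
- compound 1 `COC(=O)CN1CCN(c2c(F)cc3c(=O)c(C(=O)O)cn(C4CC4)c3c2OC)CC1C`: 500 ug/mL
- compound 2 `COc1c(N2CCN(C/C(C)=N/NC(N)=O)C(C)C2)c(F)cc2c(=O)c(C(=O)O)cn(C3CC3)c12`: 500 ug/mL
- compound 3 `COc1c(N2CCN(C/C(C)=N/NC(C)=O)C(C)C2)c(F)cc2c(=O)c(C(=O)O)cn(C3CC3)c12`: 707 ug/mL

Compound 3 gives 707 ug/mL, which lies within the scatter of compound 1 and compound 2. Compound 4 `COc1c(N2CCN(O)C(C)C2)c(F)cc2c(=O)c(C(=O)O)cn(C3CC3)c12` has not been measured. It differs from compound 3 by one oxygen atom in place of a group of 8 heavy atoms (5 carbon, 2 nitrogen, 1 oxygen; no ring), on an amine nitrogen in a ring. The measured steps all vary the group on that amine nitrogen: no change at the digits printed from compound 1 to compound 2 (within the scatter), a 1.4-fold higher number from compound 1 to compound 3 (0.15 log units; within the scatter) and a 1.4-fold higher number from compound 2 to compound 3 (0.15 log units; within the scatter). None leaves the scatter, but none tests a lone hydroxy there, so the evidence is indirect. No step beyond the scatter is therefore expected in this assay. The expected change is a 1.4-fold lower number from compound 3 to compound 4 (0.15 log units; within the scatter). For compound 4 the estimated value is 500 ug/mL, with an expected range of 200 ug/mL to 1000 ug/mL.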

Compound 4, half-maximal cytotoxic concentration: 19.7 ug/mL
Estimate against measurement, compound 4: 25-fold (1.40 log units) above, outside the stated range (below it).
By their numbers in this assay, from the lowest: compound 4; then compounds 1, 2 and 3 (each within the scatter of the next).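

In this assay the amine nitrogen in the ring proves sensitive to the group it carries: hydroxy there brings a 36-fold lower number from compound 3 to compound 4 (1.55 log units; beyond the scatter), along with a 25-fold lower number from compound 2 to compound 4 (1.40 log units; beyond the scatter) and a 25-fold lower number from compound 1 to compound 4 (1.40 log units; beyond the scatter). Among these compounds, the chains on this nitrogen in the earlier compounds stayed within the scatter of one another, so hydroxy is the first group here to leave it. Nothing available gives a reason for this drop. On these data alone, whether the drop follows from hydroxy itself or from the absence of a chain stays open; methyl, an amine or a 2-hydroxyethyl chain on this nitrogen would separate the two.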